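Swapping the aryl group on the piperazine ring

The source may report more compounds than this note shows. Statements on the series, on what has been measured and on what is new or still open speak of the compounds shown alone.

Measured compounds in a functional assay on CHO cells with adenosine receptor A1 (Homo sapiens) as the target, read by cAMP accumulation and immunoassay, with a stated time of 6 min, tested at 0.1 uM; on this read-out lower numbers stand for a stronger effect and higher numbers for a weaker effect at the one concentration tested:
- compound 1, `Nc1scc(CN2CCN(c3ccc(Cl)cc3Cl)CC2)c1C(=O)c1ccc(Cl)cc1`: -11%
- compound 2, `Nc1scc(CN2CCN(c3cccc(Cl)c3Cl)CC2)c1C(=O)c1ccc(Cl)cc1`: 3.2%
- compound 3, `Nc1scc(CN2CCN(c3ccccc3C(F)(F)F)CC2)c1C(=O)c1ccc(Cl)cc1`: -7.5%

Compound 1 has the lowest of the three numbers in this assay. The nearest is compound 3, a step of a number 3.5 percentage points higher from compound 1 to compound 3 (within the scatter); the furthest is compound 2, a step of a number 14.2 percentage points higher from compound 1 to compound 2 (beyond the scatter). Between compound 2 and compound 3 the step is a number 10.7 percentage points lower from compound 2 to compound 3 (beyond the scatter).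

Compound 4, `Nc1scc(CN2CCN(c3ccccc3F)CC2)c1C(=O)c1ccc(Cl)cc1`, has not been measured. It differs from compound 1 in one place: 2-fluorophenyl in place of 2,4-dichlorophenyl on an amine nitrogen in a ring.

Going by the values given here, two measured steps bear on this change, as each also swaps the aryl group on the same ring nitrogen of compound 1. Moving to 2,3-dichlorophenyl gave a number 14.2 percentage points higher from compound 1 to compound 2 (beyond the scatter), beyond the scatter; moving to 2-(trifluoromethyl)phenyl gave a number 3.5 percentage points higher from compound 1 to compound 3 (within the scatter), within the scatter. Compound 4 keeps a single small group on the ring, like compound 3, so a shift of similar modest size, upward from compound 1 or none beyond the scatter, is expected.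

For compound 4 the expected step is a number 6 percentage points higher from compound 1 to compound 4 (within the scatter). Compound 4 is therefore estimated at -5%, within a range from -20% to 10%.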

Compound 4, a percentage reported as activity, at one concentration (the size of the read-out at that concentration, not a potency): -1%
Compound 4: middle estimate off by 4 percentage points, on the low side; the range from low to high includes it.
By their numbers in this assay, from the lowest: compounds 1, 3, 4 and 2 (each within the scatter of the next, the first and the last beyond it).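

Read in this assay, replacing 2,4-dichlorophenyl with 2-fluorophenyl gives a number 10 percentage points higher from compound 1 to compound 4 (within the scatter) so the two chlorines of compound 1 can be exchanged for one fluorine without a shift beyond the usual scatter. The new compound also sits close to the two other aryl variants, with a number 6.5 percentage points higher from compound 3 to compound 4 (within the scatter) and a number 4.2 percentage points lower from compound 2 to compound 4 (within the scatter) so it falls within the scatter of both compound 1 and compound 2, even though those two lie beyond the scatter of each other; the new result therefore adds no clear step at this position and does not place the 2-fluorophenyl group firmly with either of them. Nothing shown here gives a reason for these small differences.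

Every aryl group shown carries halogen atoms or a trifluoromethyl group, so the compounds leave open what a plain phenyl ring, or a phenyl ring bearing a methoxy group or an amine, would do on the same ring nitrogen. With only one concentration tested, the numbers also leave open how these compounds compare in potency.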